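This account rests on a few compounds, and the source may have more. Where it says the series, first, only, none or still open, it means among the compounds named here.

Measured so far in a functional assay on SW-620 cells (Homo sapiens); a lower number here means a stronger inhibitor, a higher number a weaker inhibitor:

- compound 1 `COc1cc(NC(C)CCCNC(=O)NC(CO)(CO)CO)c2ncccc2c1`: > 100000 nM
- compound 2 `COc1cc(NC(C)CCCNC(=O)NCCNC(=O)NCCCC(C)Nc2cc(OC)cc3cccnc23)c2ncccc2c1`: 17000 nM

Compound 1 stands at the limit of > 100000 nM in this assay, at which 1 of the 2 values shown sits. That reading is a limit of the assay, not a number.

Compound 3 `CCOC(=O)NCCCC(C)Nc1cc(OC)cc2cccnc12` keeps the core of compound 1 but has ethoxy in place of (2-hydroxy-1,1-bis(hydroxymethyl)ethyl)amino on a carbonyl carbon.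

No measured single-place change is available as a guide, so the expectation rests on little. Compound 2, which shares the core, gives 17000 nM, a real number in this assay, so a measurable result seems reachable. A clear move towards stronger inhibition, beyond the usual scatter, is therefore expected. The estimated step is an at least 3.3-fold lower number from compound 1 to compound 3 (0.52 log units; beyond the scatter). For compound 3 the estimated value is 30000 nM, with an expected range of 8000 nM to 90000 nM.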

Compound 3, half-maximal inhibitory concentration: 45000 nM
The estimate for compound 3 lay 1.5-fold (0.18 log units) below the measured number; measured number inside the range.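

In this assay, putting ethoxy in place of (2-hydroxy-1,1-bis(hydroxymethyl)ethyl)amino on a carbonyl carbon gives an at least 2.2-fold lower number from compound 1 to compound 3 (0.34 log units; beyond the scatter). Within the data shown here, this is the first single-place change to read at this position, and it shows that the group on this carbonyl carbon can decide whether the shared core gives a measurable number at all, here 45000 nM for compound 3. The step has a minimum size but no exact size because compound 1 stands at a limit, which is not a number: the limit of > 100000 nM in this assay, at which 1 of the 3 values shown sits.

The change alters the heavy-atom count and the hydrogen-bond donors and acceptors all at once, so the compounds shown cannot say which of these differences matters. As far as these compounds go, whether a simple amine, a carboxylic acid or a longer chain in this place would give a lower number remains open.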